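Thiazole in place of methylpyridine on a thiourea nitrogen

This account rests on a few compounds, and the source may have more. Where it says the series, first, only, none or still open, it means among the compounds named here.

Measured compounds:
compound 1, `C[C@H](/N=C(\S)Nc1nccs1)c1cccc2ccccc12`, > 100000 nM
compound 2, `Cc1ccc(N/C(S)=N/[C@H](C)c2cccc3ccccc23)nc1`, 5 nM

For the measured compounds named here, compound 2, `Cc1ccc(N/C(S)=N/[C@H](C)c2cccc3ccccc23)nc1`, is the only compound with a number in a functional assay on RBL-2H3 cells (Rattus norvegicus) for inhibition; a lower number here means a stronger inhibitor, a higher number a weaker inhibitor; in this assay compound 2 gives 5 nM. Compound 1, `C[C@H](/N=C(\S)Nc1nccs1)c1cccc2ccccc12`, returns only a limit of the assay, > 100000 nM, and no number. That limit is where one of the two values shown sits (the limit of > 100000 nM in this assay, at which 1 of the 2 values shown sits).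

Compound 3, `C[C@@H](/N=C(\S)Nc1nccs1)c1cccc2ccccc12`, has not yet been measured. Its difference from compound 2 is 1,3-thiazol-2-yl in place of 5-methylpyridin-2-yl on an amine nitrogen. Going by the values given here, no measured pair shows what this change does, so the expected step rests on compound 2 alone. The thiazolyl group is smaller than the methylpyridinyl group it replaces and brings a second hydrogen-bond acceptor; how that affects the inhibition is not shown by the numbers at hand.

The step from compound 2 to compound 3 is expected to be a modest loss, a 6.0-fold higher number from compound 2 to compound 3 (0.78 log units; beyond the scatter), somewhat beyond the scatter. Compound 3 is therefore estimated at 30 nM, within 5 nM to 300 nM.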

Compound 3, half-maximal inhibitory concentration: > 100000 nM
Compound 3 was reported as a limit; the forecaster's own chance of this, stated with the estimate: 5%; at least 3300-fold (3.52 log units) between middle value and limit.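

In this assay, 1,3-thiazol-2-yl in place of 5-methylpyridin-2-yl on the amine nitrogen gives an at least 20000-fold higher number from compound 2 to compound 3 (4.30 log units; beyond the scatter), a large step that leaves the new compound at a limit of the assay rather than at a number. Compound 1 could not show this on its own, as it differs from compound 2 in the configuration as drawn as well as in this group, whereas the present step involves the group alone. Neither configuration as drawn gives a thiazolyl compound with a number, and both stop at the same limit: the limit of > 100000 nM in this assay, at which 2 of the 3 values shown sit.

Going by these compounds, the step from compound 1 to compound 3 cannot be read, as both values are limits, so what configuration contributes among the thiazolyl compounds stays open: the fact that compounds 1 and 3 differ only in the configuration as drawn. Also open, on these data alone, is what on the amine nitrogen the inhibition depends on, whether the six-membered ring, its ring nitrogen or its methyl group, and a plain pyridin-2-yl or a phenyl group in the same place would begin to separate these.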